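A few compounds are considered here, and "the series" means these few. Any claim that something is new, unique, unknown or untested is made for them only; others in the source may bear on it.

Measured compounds:
compound 1 `COc1ccc(OC)c(C2=NOC(COc3ccc(-c4nnnn4-c4cc(OC)c(OC)c(OC)c4)cc3N)C2)c1` — 3500 nM
compound 2 `COc1ccc(C2=NOC(COc3ccc(-c4nnnn4-c4cc(OC)c(OC)c(OC)c4)cc3N)C2)cc1OC` — 3570 nM

In a functional assay on MDA-MB-231 cells (Homo sapiens) for cytotoxicity, read by MTT assay, with a stated time of 48 h (a higher number here means a weaker inhibitor, a lower number a stronger inhibitor), compound 1 gives 3500 nM. Going by the values given here, compound 2 gives 3570 nM, and the step of a 1.0-fold higher number from compound 1 to compound 2 (0.01 log units; within the scatter) lies within the scatter, so the two measured numbers cannot be told apart; compound 1 stands level with its only neighbour and no rank between them can be stated.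

Compound 3 `COc1cc(-n2nnnc2-c2ccc(OCC3CC(c4ccc(C(F)(F)F)cc4)=NO3)c(N)c2)cc(OC)c1OC` has not yet been tested in this assay. Against compound 1 it differs as follows: 4-(trifluoromethyl)phenyl in place of 2,5-dimethoxyphenyl on a carbon with a double bond to nitrogen. Among the compounds with values here, the one measured step, from compound 1 to compound 2, also alters the group on this same carbon, moving the two methoxy groups around the ring, and it produced no shift beyond the scatter. Within the data shown here, that is the only step bearing on the position, and it does not cover an exchange of a dimethoxyphenyl for a 4-(trifluoromethyl)phenyl, so there is no measured precedent for the direction of this change.

With only a null step at this position to go on, the expected step of no change at the digits printed from compound 1 to compound 3 (within the scatter) is none beyond the scatter, with a wide margin for the untested exchange. For compound 3 the estimate in this assay is 3500 nM, with a range from 1200 nM to 10000 nM.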

Compound 3, half-maximal inhibitory concentration: 1750 nM
For compound 3 the middle estimate is 2.0-fold (0.30 log units) above the measured one; the range from low to high includes it.
By their numbers in this assay, from the lowest: compounds 3, 1 and 2 (each within the scatter of the next, the first and the last beyond it).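

The exchange of either dimethoxyphenyl group for 4-(trifluoromethyl)phenyl on the carbon with a double bond to nitrogen is tolerated in this assay, so the methoxy groups are not needed to keep a number of this size in these cells. The two readings of the exchange differ only slightly: a 2.0-fold lower number from compound 2 to compound 3 (0.31 log units; beyond the scatter) is modest, while a 2.0-fold lower number from compound 1 to compound 3 (0.30 log units; within the scatter) does not separate the pair, so compound 3 cannot be ranked ahead of compound 1. Any gain from this exchange is therefore small, yet this is the first comparison at the position to reach beyond the scatter, which the shift of methoxy groups between compound 1 and compound 2 did not do.

As far as these compounds go, it remains open whether the trifluoromethyl group or the loss of the methoxy groups matters here, a question that an unsubstituted phenyl, a 4-chlorophenyl or a 4-methylphenyl at the same carbon could help to separate, as could an amine or a carboxylic acid on that ring. Nothing among the data shown explains the result.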